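A longer chain on compound 2

This account rests on a few compounds, and the source may have more. Where it says the series, first, only, none or still open, it means among the compounds named here.

compound 1 `COc1ccc(-c2c(C)[nH]c(=O)n2C)cc1` gives 147000 nM
compound 2 `CCCCCCOc1ccc(-c2c(C)[nH]c(=O)n2C)cc1` gives 7300 nM

In a functional assay on brain (Rattus norvegicus, strain Wistar) for inhibition (on this read-out lower numbers stand for stronger inhibition and higher numbers for weaker inhibition), compound 2 gives 7300 nM and so holds the lower of the two numbers measured. The next compound, compound 3 `CCCCCCCCOc1ccc(-c2c(C)[nH]c(=O)n2C)cc1`, differs from it by one change, (ethyl in place of hydrogen on a saturated chain carbon, six bonds along the chain from an oxygen on an aromatic ring), with ethyl in place of hydrogen on a saturated chain carbon, six bonds along the chain from an oxygen on an aromatic ring. For the measured compounds named here, one measured step bears on this, a 20-fold lower number from compound 1 to compound 2 (1.30 log units; beyond the scatter), which extended the same chain by pentyl. On the strength of that single large step, a smaller step in the same direction is expected in this assay for the shorter addition, although one step cannot show whether the trend continues. The estimated step is a 2.4-fold lower number from compound 2 to compound 3 (0.39 log units; beyond the scatter) and it remains uncertain. For compound 3 the expected value is 3000 nM with an estimated range of 800 nM to 12000 nM around it.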

Compound 3, half-maximal inhibitory concentration: 4000 nM
Beside the measured number, compound 3's estimate is 1.3-fold (0.12 log units) below it, and the stated range covers the measured number.
By their numbers in this assay, from the lowest: compounds 3 and 2 (each within the scatter of the next); then compound 1.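

In this assay, adding ethyl on a saturated chain carbon, six bonds along the chain from an oxygen on an aromatic ring, gives a 1.8-fold lower number from compound 2 to compound 3 (0.26 log units; within the scatter), so this further extension does not separate the two compounds. The large gain seen on the first extension therefore does not measurably carry on at this chain length, even though the whole change still amounts to a 37-fold lower number from compound 1 to compound 3 (1.57 log units; beyond the scatter). Nothing available here explains this result.

On these data alone, whether a longer chain would stay level with compound 3 or move away from it remains open. As far as these compounds go, it is also open whether an amine or a carboxylic acid in place of the ethyl, at the same place, would read differently from compound 3.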